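Aryl in place of arylethynyl on the shared core

The source may report more compounds than this note shows. Statements on the series, on what has been measured and on what is new or still open speak of the compounds shown alone.

Compound 1 `Nc1ncnn2c([C@@H]3O[C@H](CO)[C@@H](O)[C@H]3O)cc(C#Cc3ccc(F)cc3)c12` returns only a limit in a functional assay on HCT-116 cells (Homo sapiens) for antiproliferative activity, with a stated time of 72 h (on this read-out higher numbers stand for weaker inhibition and lower numbers for stronger inhibition), reported as > 100000 nM; this is the limit of > 100000 nM in this assay, at which 1 of the 3 values shown sits. Compound 2 `Nc1ncnn2c([C@@H]3O[C@H](CO)[C@@H](O)[C@H]3O)cc(C#Cc3cccs3)c12` gives 65500 nM in this assay. Compound 3 `Nc1ncnn2c([C@@H]3O[C@H](CO)[C@@H](O)[C@H]3O)cc(-c3ccc(Cl)cc3)c12` gives 59300 nM in this assay. Of the two numbers shown, compound 2 stands highest, with compound 3 nearest, and the two lie within the scatter of each other, as a 1.1-fold lower number from compound 2 to compound 3 (0.04 log units; within the scatter) shows. The steps away from the limit of compound 1 are floors only: an at least 1.5-fold lower number from compound 1 to compound 2 (0.18 log units; that floor lies within the scatter) and an at least 1.6-fold lower number from compound 1 to compound 3 (0.22 log units; that floor lies within the scatter).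

Compound 4 `Cc1ccccc1-c1cc([C@@H]2O[C@H](CO)[C@@H](O)[C@H]2O)n2ncnc(N)c12` differs from compound 2 in one place: 2-methylphenyl in place of 2-(thiophen-2-yl)ethynyl on an aromatic carbon. The measured step that bears on this change is a 1.1-fold lower number from compound 2 to compound 3 (0.04 log units; within the scatter), in which a six-membered aromatic ring of carbon only likewise takes the place of an arylethynyl group on an aromatic carbon, with no movement beyond the scatter. The bound an at least 1.6-fold lower number from compound 1 to compound 3 (0.22 log units; that floor lies within the scatter) adds nothing beyond a floor within the scatter. No step beyond the scatter is therefore expected in this assay for the change to compound 4; the expected step is a 1.2-fold lower number from compound 2 to compound 4 (0.08 log units; within the scatter). Compound 4 is estimated at 55000 nM, expected between 20000 nM and 150000 nM.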

Compound 4, half-maximal inhibitory concentration: > 100000 nM
Compound 4 ended at the assay's limit; the forecaster's own chance of this, stated with the estimate: 25%; middle value at least 1.8-fold (0.25 log units) away from the limit.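

In this assay compound 4 is recorded only as a limit, and compound 1 also remains a limit: the limit of > 100000 nM in this assay, at which 2 of the 4 values shown sit.

The readable steps are floors only, an at least 1.5-fold higher number from compound 2 to compound 4 (0.18 log units; that floor lies within the scatter) and an at least 1.6-fold higher number from compound 3 to compound 4 (0.22 log units; that floor lies within the scatter), while the step from compound 1 to compound 4 cannot be read because both values are limits. On this aromatic carbon, the arylethynyl and directly attached aryl groups therefore do not sort the four compounds, as each kind now has one member with a number and one at the limit.

Going by these compounds, whether 2-methylphenyl truly differs from 4-chlorophenyl stays open, and 4-methylphenyl or 2-chlorophenyl would separate the substituent from its place on the ring. On these data alone, how an aminomethyl group or a carboxylic acid on that ring would read also remains open.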